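Amide variation on the shared core: two inactive limits so far

This account rests on a few compounds, and the source may have more. Where it says the series, first, only, none or still open, it means among the compounds named here.

Compound 1 `CC(=O)Nc1nccc2ncc(-c3cnn(C)c3)cc12`: > 50000 nM
Compound 2 `Cn1cc(-c2cnc3ccnc(NC(=O)C4CC4)c3c2)cn1`: > 50000 nM

In a functional assay on A549 cells (Homo sapiens) for antiproliferative activity, read by MTT assay, with a stated time of 48 h (a lower number here means a stronger inhibitor, a higher number a weaker inhibitor), compound 1 reaches only a limit, > 50000 nM. In this assay compound 2 likewise gives only a limit, > 50000 nM. The step that the two limits leave unreadable from compound 1 to compound 2 therefore cannot be read; both values sit at the limit of > 50000 nM in this assay, at which 2 of the 2 values shown sit. Compound 3 `Cn1cc(-c2cnc3ccnc(NC(=O)c4ccc(F)cc4)c3c2)cn1` differs from compound 2 by 4-fluorophenyl in place of cyclopropyl on a carbonyl carbon. For the measured compounds named here, no measured step bears on this change, and nothing in the pair so far reaches a number. For compound 3 the step that the limit leaves unreadable from compound 2 to compound 3 is expected to stay within the scatter, most likely again a limit. Compound 3 is thus estimated at 60000 nM, between 15000 nM and 300000 nM.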

Compound 3, half-maximal inhibitory concentration: > 50000 nM
Compound 3: only a limit was reported; the forecaster's own chance of this, stated with the estimate: 75%; the middle value is on the limit's open side.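

For the compounds shown here, compound 1, compound 2 and compound 3 all give only a limit, so no step among them can be read: the limit of > 50000 nM in this assay, at which 3 of the 3 values shown sit. The compounds shown leave open whether any amide on the shared core reaches a number in this assay.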